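Methyl to trifluoromethyl on the triazole aryl of compound 1

This account rests on a few compounds, and the source may have more. Where it says the series, first, only, none or still open, it means among the compounds named here.

Compound 1 `C=C1C[C@]23C[C@@]1(O)CC[C@H]2c1ccc(OS(=O)(=O)c2ccc(C)cc2)c(C)c1[C@@H]3Cn1cc(-c2ccc(C)cc2)nn1` is measured in a functional assay on SMMC-7721 cells (Homo sapiens) for cytotoxicity, read by MTT assay, with a stated time of 4 days (a higher number here means a weaker inhibitor, a lower number a stronger inhibitor), and gives only a limit of the assay: > 20000 nM. Compound 2 `C=C1C[C@]23C[C@@]1(O)CC[C@H]2c1ccc(O)c(C)c1[C@@H]3Cn1cc(-c2ccc(C)cc2)nn1` likewise reaches only a limit in this assay, > 20000 nM. Among the compounds with values here, compound 3 `C=C1C(=O)[C@]23C[C@@]1(O)CC[C@H]2c1ccc(O)c(C)c1[C@@H]3Cn1cc(-c2ccc(C)cc2)nn1` is the one member of the series with a number in this assay, at 920 nM. Within the data shown here, the single step within the measured set, a step that the two limits leave unreadable from compound 1 to compound 2, runs between two limits and so cannot be read; the two limits are also what the limit of > 20000 nM in this assay, at which 2 of the 3 values shown sit, records for the series. Compound 4 `C=C1C[C@]23C[C@@]1(O)CC[C@H]2c1ccc(OS(=O)(=O)c2ccc(C)cc2)c(C)c1[C@@H]3Cn1cc(-c2ccc(C(F)(F)F)cc2)nn1` is yet to be measured in this assay. It differs from compound 1 by trifluoromethyl in place of methyl on an aromatic carbon, on the aryl group carried by the triazole. Among the measured compounds shown here, no measured step touches this aryl group, so nothing speaks to the size or direction of the change. Since compound 1 sits at the limit of this assay with > 20000 nM, the most that the data support is the expectation that compound 4 stays at or near that limit, an estimated step that the limit leaves unreadable from compound 1 to compound 4. For compound 4 the estimate in this assay is therefore 30000 nM, within 8000 nM to 100000 nM, with a limit rather than a number the likelier outcome.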

Compound 4, half-maximal inhibitory concentration: > 20000 nM
Compound 4 ended at the assay's limit; the forecaster's own chance of this, stated with the estimate: 80%; the middle value does not contradict the limit.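

In this assay compound 4 gives > 20000 nM, a limit and not a number. Within the data shown here, compound 1 also gives a limit, > 20000 nM, so no step from compound 1 to compound 4 can be read: the limit of > 20000 nM in this assay, at which 3 of the 4 values shown sit. The compounds shown leave open what 4-methylphenyl to 4-(trifluoromethyl)phenyl does in a compound that gives a number in this assay.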